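Amide cap change on the shared core: compound 2 to compound 3

The compounds below may be only part of what the source reports. "The series", "measured", "known", "first", "only" and "open" are said of these compounds alone.

Compound 1, `CN1[C@@H]2c3[nH]c4ccccc4c3C[C@H]1[C@H](C#N)N1[C@@H](CNC(=O)c3ccc(Cl)cc3)c3[nH]c4ccccc4c3C[C@@H]21`, gives 350 nM in a functional assay on HepG2 cells (Homo sapiens) for cytotoxicity, read by MTT assay, with a stated time of 72 h; on this read-out higher numbers stand for weaker inhibition and lower numbers for stronger inhibition.
Compound 2, `CN1[C@@H]2c3[nH]c4ccccc4c3C[C@H]1[C@H](C#N)N1[C@@H](CNC(=O)c3cc4ccccc4s3)c3[nH]c4ccccc4c3C[C@@H]21`, gives 300 nM in this assay.

On these two numbers compound 2 holds the lower figure, yet the step of a 1.2-fold lower number from compound 1 to compound 2 (0.07 log units; within the scatter) falls within the scatter, so the two compounds cannot be ordered. Compound 3, `CN1[C@@H]2c3[nH]c4ccccc4c3C[C@H]1[C@H](C#N)N1[C@@H](CNC(=O)/C=C/c3ccccc3)c3[nH]c4ccccc4c3C[C@@H]21`, carries the difference (2-phenylethenyl in place of 1-benzothiophen-2-yl on a carbonyl carbon). Among the measured compounds shown here, the only measured step that bears on this position is a 1.2-fold lower number from compound 1 to compound 2 (0.07 log units; within the scatter), where one aromatic cap replaced another on the same carbonyl carbon without a change beyond the scatter. A second change of the cap on that carbonyl carbon is therefore expected to give no step beyond the scatter, so compound 3 is estimated at 300 nM, with a range from 120 nM to 800 nM, which amounts to an expected step of no change at the digits printed from compound 2 to compound 3 (within the scatter).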

Compound 3, half-maximal inhibitory concentration: 470 nM
Estimate against measurement, compound 3: 1.6-fold (0.19 log units) below, within the range that was stated.
By their numbers in this assay, from the lowest: compounds 2, 1 and 3 (each within the scatter of the next).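

In this assay, putting 2-phenylethenyl on the carbonyl carbon in place of 1-benzothiophen-2-yl gives a 1.6-fold higher number from compound 2 to compound 3 (0.19 log units; within the scatter) and in place of 4-chlorophenyl gives a 1.3-fold higher number from compound 1 to compound 3 (0.13 log units; within the scatter) on the shared core. Among the compounds shown here, the earlier pair had only aromatic rings as caps, whereas compound 3 carries a double bond outside aromatic rings and neither the sulfur of compound 2 nor the chlorine of compound 1, and still no step among the three compounds leaves the scatter. The position has therefore now taken three different caps without a step that can be read as a change, though this holds only for these three compounds. The compounds shown leave open whether a cap with no aromatic ring, such as cyclohexyl, or a longer chain ending in an amine or a carboxylic acid, would stay within the scatter of these values. No measurement is available here that would explain the small differences among these caps.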